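The compounds below may be only part of what the source reports. "The series", "measured", "known", "first", "only" and "open" are said of these compounds alone.

Within the data shown here, in a functional assay on the whole organism for antagonist activity, with Rattus norvegicus as the target (a higher number here means that more compound is needed for the effect, a lower number that less compound is needed), compound 1 `c1ccc2c(c1)CC2CCCN1CCN(c2cccc3c2OCCO3)CC1` gives 0.18 mg/kg and stands lowest of the two numbers so far, while compound 2 `Clc1cccc2c1CC2CCN1CCN(c2cccc3c2OCCO3)CC1` gives 1.13 mg/kg as the higher one. Compound 3 `Clc1cccc2c1CC2CCCN1CCN(c2cccc3c2OCCO3)CC1` keeps the chain of compound 1 and changes one place, with chloro in place of hydrogen on an aromatic carbon and nothing else. Among the measured compounds shown here, only one measured step bears on this, and a 6.3-fold higher number from compound 1 to compound 2 (0.80 log units; beyond the scatter) brings in the same chloro but also shortens the chain, so the share of the chloro alone remains unknown. For the measured compounds named here, with compound 2 at 1.13 mg/kg as the only chlorine-bearing guide, and part of its step perhaps belonging to the chain, a smaller step towards a higher number is expected in this assay for compound 3 rather than a full repeat. The expected step is a 2.2-fold higher number from compound 1 to compound 3 (0.35 log units; beyond the scatter) with a wide margin. For compound 3 the estimated value is 0.4 mg/kg with a range from 0.13 mg/kg to 1.2 mg/kg in this estimate.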

Compound 3, dose for 50% inhibition: 3.09 mg/kg
For compound 3 the middle estimate is 7.7-fold (0.89 log units) below the measured one; measured number above the stated range.
By their numbers in this assay, from the lowest: compound 1; then compound 2; then compound 3.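

In this assay, the chloro on this aromatic carbon can now be read alone, and it is costly: a 17-fold higher number from compound 1 to compound 3 (1.23 log units; beyond the scatter). That step is larger than a 6.3-fold higher number from compound 1 to compound 2 (0.80 log units; beyond the scatter), where the chain also differs, and among the chlorine-bearing compounds, compound 2 gives 1.13 mg/kg with the shorter chain while compound 3 gives 3.09 mg/kg with the chain of compound 1, so the effect of the chloro does not simply add to that of the chain. No measurement available here explains why this single atom changes the number so much.

Open, as far as these compounds go, is whether a smaller fluoro or a methyl group on the same aromatic carbon would raise the number as far. Also open, from the compounds shown here alone, is whether a chloro on another carbon of that aromatic ring would do the same.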